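Chloro to hydrogen on the shared core of compound 3

The compounds below may be only part of what the source reports. "The series", "measured", "known", "first", "only" and "open" are said of these compounds alone.

Measured compounds in a functional assay on MCF7 cells (Homo sapiens) for cytotoxicity, read by sulforhodamine B assay, with a stated time of 72 h; a higher number here means a weaker inhibitor, a lower number a stronger inhibitor:
Compound 1, `O=C1/C(=C/c2coc3ccccc3c2=O)N=C(c2ccc(Cl)cc2)N1c1ccc(S(=O)(=O)Nc2ncccn2)cc1`, gives > 100000 nM; this value is a limit of the assay.
Compound 2, `Cc1cc(C)nc(NS(=O)(=O)c2ccc(N3C(=O)/C(=C/c4coc5ccccc5c4=O)N=C3c3ccccc3)cc2)n1`, gives 99700 nM.
Compound 3, `O=C1/C(=C/c2coc3ccccc3c2=O)N=C(c2ccc(Cl)cc2)N1c1ccc(S(=O)(=O)Nc2ccccn2)cc1`, gives > 100000 nM; this value is a limit of the assay.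

Compound 3 thus stands at the limit of this assay, where compound 1 also sits (the limit of > 100000 nM in this assay, at which 2 of the 3 values shown sit). Among the compounds with values here, the only step between measured compounds that differ in one place, a step that the two limits leave unreadable from compound 1 to compound 3, runs between two limits and its size cannot be read.

Compound 4, `O=C1/C(=C/c2coc3ccccc3c2=O)N=C(c2ccccc2)N1c1ccc(S(=O)(=O)Nc2ccccn2)cc1`, follows from compound 3 by hydrogen in place of chloro on an aromatic carbon. Within the data shown here, no measured step concerns this change; the step that the two limits leave unreadable from compound 1 to compound 3 touches the sulfonamide nitrogen instead and is unreadable. Compound 2, which carries phenyl rather than 4-chlorophenyl together with a different sulfonamide group, returns a number that sits right at the limit. On this basis no step beyond the scatter is expected for a number no higher from compound 3 to compound 4 (the limit leaves the size open). Compound 4 is therefore estimated at 100000 nM in this assay, within 30000 nM to 300000 nM, most likely reported as a limit.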

Compound 4, half-maximal inhibitory concentration: > 100000 nM
Compound 4 ended at the assay's limit; the forecaster's own chance of this, stated with the estimate: 60%; the middle value sits exactly at the limit.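

With hydrogen in place of chloro, this position now has a second group, phenyl against 4-chlorophenyl, and with the pyridin-2-yl sulfonamide neither gives a number within the range of this assay and pyridin-2-yl in place of 4,6-dimethylpyrimidin-2-yl on the sulfonamide nitrogen gives a number no lower from compound 2 to compound 4 (the limit leaves the size open). Compound 4 gives > 100000 nM, which is a limit of the assay. The steps ending at compound 4 cannot be read, so neither the loss of chloro nor the change from 4,6-dimethylpyrimidin-2-yl to pyridin-2-yl has a size, and the series stays at one end of the scale: the limit of > 100000 nM in this assay, at which 3 of the 4 values shown sit.

Still open, on these data alone, is whether any other group on this aromatic carbon, such as an amine or a carboxylic acid, would bring a value clear of the limit. Also open, as far as these compounds go, is whether chloro matters at all once the sulfonamide nitrogen carries a group that gives a readable number.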